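The compounds below may be only part of what the source reports. "The series", "measured", "known", "first", "only" and "open" are said of these compounds alone.

In an ADME assay on microsomes from liver (Mus musculus) for metabolic stability, read by LC-MS, with NADPH named in the record, with a stated time of 60 min, tested at 1 uM, in the absence of a further agent (on this read-out higher numbers stand for a more stable compound and lower numbers for a less stable compound), compound 2 (`COc1ccc(-c2c(C)nc3c(N4CC[C@@H](O)C4)cc(C)nn23)cc1OC`) gives > 95% as its reading, which is a limit and not a number. Compound 1 (`COc1ccc(-c2c(C)nc3c(N4CC[C@@H](NS(C)(=O)=O)C4)cc(C)nn23)cc1OC`) gives > 95% as its reading, also a limit. Both compounds therefore sit together, as the limit of > 95% in this assay, at which 2 of the 2 values shown sit, shows. Among the measured compounds shown here, the only measured step is a step that the two limits leave unreadable from compound 1 to compound 2 and it has no readable size, so it offers weak guidance. Compound 3 (`COc1ccc(-c2c(C)nc3c(N4CC[C@H](O)C4)cc(C)nn23)cc1OC`) is related to compound 2 as follows: the two compounds have the same atoms and bonds and differ only in configuration as drawn: 1 of 1 stereo elements differ; a stereocentre at a saturated ring carbon is drawn R in compound 2 and S in compound 3. With no sign of lost stability in compound 2 at > 95% as its reading, no step beyond the usual scatter is expected in this assay here. The expected step is a number no higher from compound 2 to compound 3 (the limit leaves the size open) in this estimate. The estimated value for compound 3 is 95% within an expected range of 80% to 100% in all.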

Compound 3, percent of the compound remaining: > 95%
Compound 3: a limit, no number; the forecaster's own chance of this, stated with the estimate: 0.6%; the middle value sits exactly at the limit.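

No size of step can be read among compound 1, compound 2 and compound 3, because all three readings are limits and not numbers: the limit of > 95% in this assay, at which 3 of the 3 values shown sit.

Left open is how far these compounds differ in stability, including whether the configuration drawn in compound 2 and compound 3 makes any difference.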